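This account rests on a few compounds, and the source may have more. Where it says the series, first, only, none or still open, it means among the compounds named here.

In an assay on CHO cells for displacement of a labelled ligand from prostaglandin E2 receptor EP4 subtype (Mus musculus), read by scintillation counting, with a stated time of 60 min (a lower number here means a stronger inhibitor, a higher number a weaker inhibitor), compound 2 `O=C(O)CCCSCCN1C(=O)OC[C@@H]1/C=C/[C@@H](O)Cc1ccccc1` gives 4.2 nM. Among the three measured compounds its number is the second highest: compound 1 `CCc1cccc(C[C@H](O)/C=C/[C@H]2COC(=O)N2CCSCCCC(=O)O)c1` gives 7.9 nM, which lies within the scatter of compound 2, and compound 3 `CCCc1cccc(C[C@H](O)/C=C/[C@H]2CCC(=S)N2CCCCCCC(=O)O)c1` gives 0.4 nM, a lower number than compound 2 that lies beyond the scatter. Compound 4 `COCc1cccc(C[C@H](O)/C=C/[C@H]2COC(=O)N2CCSCCCC(=O)O)c1` has not yet been measured in this assay. It differs from compound 2 by methoxymethyl in place of hydrogen on an aromatic carbon. Among the measured compounds shown here, one measured step bears on this change: compound 1 carries an ethyl on the same aromatic carbon where compound 2 carries hydrogen, and a 1.9-fold lower number from compound 1 to compound 2 (0.27 log units; within the scatter). That step shows that a small group on this carbon moved the number by no more than the scatter. Methoxymethyl is another small group on the same carbon, so the expectation is a step of a 1.4-fold higher number from compound 2 to compound 4 (0.15 log units; within the scatter), a change no larger than the scatter, if anything toward a somewhat higher number. The estimate for compound 4 is 6 nM, with a range from 2.5 nM to 15 nM.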

Compound 4, inhibition constant: 7.2 nM
Beside the measured number, compound 4's estimate is 1.2-fold (0.08 log units) below it; the measured number falls inside the stated range.
By their numbers in this assay, from the lowest: compound 3; then compounds 2, 4 and 1 (each within the scatter of the next).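

Methoxymethyl in place of hydrogen on this aromatic carbon gives a 1.7-fold higher number from compound 2 to compound 4 (0.23 log units; within the scatter) and so joins ethyl as a second group here that stays within the scatter of hydrogen. It also brings an oxygen and a hydrogen-bond acceptor, which ethyl lacks, yet methoxy in place of methyl on the chain carbon gives a 1.1-fold lower number from compound 1 to compound 4 (0.04 log units; within the scatter) and so separates the two substituted compounds by no more than the scatter. No measurement at hand explains why these groups are tolerated on this carbon.

On these data alone, whether an amine, a carboxylic acid or a longer chain on this carbon would also stay within the scatter remains open. Compound 3 differs from these compounds in more than one place, so its lower number cannot be traced to any single change.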